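Distal urea aryl variation in the V804L series

The source may report more compounds than this note shows. Statements on the series, on what has been measured and on what is new or still open speak of the compounds shown alone.

Measured so far:
Compound 1 `O=C(Nc1ccc(Cl)cc1)Nc1ccc(Nc2ncnc3c2OCCN3)cc1` — in an assay on isolated protein for inhibition of proto-oncogene tyrosine-protein kinase receptor Ret variant V804L (Homo sapiens), read by 33P incorporation, with stated times of 15 min and 40 min (on this read-out higher numbers stand for weaker inhibition and lower numbers for stronger inhibition), compound 1 gives > 10000 nM, a limit of the assay.
Compound 2 `O=C(Nc1ccc(Nc2ncnc3c2OCCN3)cc1)Nc1cc(Cl)cc(Cl)c1` — in this assay compound 2 gives 4480 nM.
Compound 3 `O=C(Nc1ccc(Nc2ncnc3c2OCCN3)cc1)Nc1cccc2ccccc12` — in this assay compound 3 gives > 10000 nM, a limit of the assay.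

Compound 3 therefore stands at the upper limit of this assay, where two of the three values sit (the limit of > 10000 nM in this assay, at which 2 of the 3 values shown sit); no number is known for it. Compound 4 `CC(C)(C)c1cc(NC(=O)Nc2ccc(Nc3ncnc4c3OCCN4)cc2)no1` differs from it by 5-(tert-butyl)-1,2-oxazol-3-yl in place of naphthalen-1-yl on an amide-type nitrogen. Among the compounds with values here, of the measured steps, the one from compound 2 to compound 3 is the one that bears most directly on this change, since it replaces the same naphthalen-1-yl group: an at least 2.2-fold higher number from compound 2 to compound 3 (0.34 log units; beyond the scatter). The step that the two limits leave unreadable from compound 1 to compound 3 adds nothing readable, as both ends sit at the limit, and an at least 2.2-fold lower number from compound 1 to compound 2 (0.34 log units; beyond the scatter) shows that the distal aryl group does move the number within this small set. Within the data shown here, since the naphthalen-1-yl group is the weaker end of the only readable step, its removal is expected to give a lower number, at least modest, an at least 3.3-fold lower number from compound 3 to compound 4 (0.52 log units; beyond the scatter). Compound 4 is estimated at 3000 nM, with a range from 600 nM to 12000 nM in this assay.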

Compound 4, half-maximal inhibitory concentration: 58 nM
Beside the measured number, compound 4's estimate is 52-fold (1.71 log units) above it; the whole stated range lies above it.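

At this position, on an amide-type nitrogen, the group carried decides whether the series reads at all in this assay: 5-(tert-butyl)-1,2-oxazol-3-yl gives an at least 170-fold lower number from compound 3 to compound 4 (2.23 log units; beyond the scatter), and the same group gives an at least 170-fold lower number from compound 1 to compound 4 (2.23 log units; beyond the scatter) and a 77-fold lower number from compound 2 to compound 4 (1.89 log units; beyond the scatter). Before this result, the three aryl groups shown, 4-chlorophenyl, 3,5-dichlorophenyl and naphthalen-1-yl, gave no readable value better than that of compound 2 at 4480 nM, whereas the step to the five-membered aromatic ring with 2 hetero atoms is large from all three. Compound 1 and compound 3 stand at a limit of the assay and not at a number, so the two steps that start from them give only a minimum size: the limit of > 10000 nM in this assay, at which 2 of the 4 values shown sit.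

Compound 4 brings the ring and the tert-butyl in together, so the compounds shown do not tell which of the two carries the step. Going by these compounds, a methyl or a trifluoromethyl in place of the tert-butyl, or a tert-butylphenyl in place of the whole 5-(tert-butyl)-1,2-oxazol-3-yl, would separate the two, and how far the step holds on other cores remains open.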